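The source may hold more compounds than are shown below. What is called first, only, known or untested is meant among the compounds shown, and "the series" means these compounds.

Three compounds share one core and differ only in the ring attached to the sulfonyl sulfur. Compound 1 `Cn1c(=O)c(S(=O)(=O)c2ccc(F)cc2F)cc2cnc(Nc3ccc4cc[nH]c4c3)nc21` carries a 2,4-difluorophenyl there, compound 2 `Cn1c(=O)c(S(=O)(=O)c2ccccc2)cc2cnc(Nc3ccc4cc[nH]c4c3)nc21` a phenyl, and compound 3 `Cc1ccc(S(=O)(=O)c2cc3cnc(Nc4ccc5cc[nH]c5c4)nc3n(C)c2=O)cc1` a 4-methylphenyl. In a functional assay on DU-145 cells (Homo sapiens) for inhibition, read by trypan blue exclusion, with a stated time of 72 h (on this read-out lower numbers stand for stronger inhibition and higher numbers for weaker inhibition), compound 1 gives 5000 nM, compound 2 gives 10000 nM, and compound 3 gives 15000 nM. Compound 2 stands second highest of the three numbers; the steps of a 2.0-fold higher number from compound 1 to compound 2 (0.30 log units; within the scatter) and a 1.5-fold higher number from compound 2 to compound 3 (0.18 log units; within the scatter) are both within the scatter, and only a 3.0-fold higher number from compound 1 to compound 3 (0.48 log units; beyond the scatter) is a modest step beyond it.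

Compound 4 `Cn1c(=O)c(S(=O)(=O)c2ccccc2)cc2cnc(Nc3cnc4[nH]ccc4c3)nc21` keeps the phenyl on the sulfonyl sulfur of compound 2 and changes instead the ring on the amine nitrogen: a group of 9 heavy atoms (7 carbon, 2 nitrogen; one five-membered aromatic ring with 1 hetero atom, one six-membered aromatic ring with 1 hetero atom) in place of a group of 9 heavy atoms (8 carbon, 1 nitrogen; one five-membered aromatic ring with 1 hetero atom, one six-membered aromatic ring of carbon only), on a nitrogen on an aromatic ring. Among the measured compounds shown here, none of the measured steps touches that position; all three alter the sulfonyl aryl group, so there is no direct precedent for this change. The measured steps are small, and with nothing to point either way, the step of no change at the digits printed from compound 2 to compound 4 (within the scatter) is expected to stay within the scatter. Compound 4 is therefore estimated to give 10000 nM in this assay, with a plausible range from 3000 nM to 30000 nM.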

Compound 4, half-maximal inhibitory concentration: 1000 nM
Compound 4: the middle estimate sits 10-fold (1.00 log units) above what was measured, and the stated range ends above it.
By their numbers in this assay, from the lowest: compound 4; then compounds 1, 2 and 3 (each within the scatter of the next, the first and the last beyond it).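

Among the compounds shown here, the ring on the amine nitrogen matters far more in this assay than the earlier compounds could show: the change from 1H-indol-6-yl to the group with a hetero atom in its six-membered ring gives a 10-fold lower number from compound 2 to compound 4 (1.00 log units; beyond the scatter). That step is larger than the biggest step seen on the sulfonyl aryl group, a 3.0-fold higher number from compound 1 to compound 3 (0.48 log units; beyond the scatter), even though the two amine groups have the same heavy-atom count and the entering group differs by one ring nitrogen in place of a carbon and by one added hydrogen-bond acceptor. Nothing here gives a measured reason for the gain, so the result records that this position responds to the change but not how it does so.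

As far as these compounds go, it remains open whether the same ring change would lower the number to a similar extent with the 2,4-difluorophenyl or 4-methylphenyl group on the sulfonyl sulfur, since only the phenyl pair can be read. Also unknown is how this position would respond to a ring carrying a further substituent, such as a piperazine or a carboxylic acid, on the group attached to the amine nitrogen.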